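Methyl in place of tert-butoxy on compound 3

The compounds below may be only part of what the source reports. "The series", "measured", "known", "first", "only" and "open" are said of these compounds alone.

Measured in a functional assay on NALM-6 cells (Homo sapiens) for cytotoxicity, with a stated time of 72 h; on this read-out higher numbers stand for an effect only at larger amounts of compound and lower numbers for an effect already at smaller amounts:
Compound 1 `COc1ccc(/C=C/[C@@](C)(/C=C/c2ccc(O)c(C=O)c2)CCC=C(C)C)cc1`: > 43400 nM (a limit)
Compound 2 `COc1ccc(/C=C/[C@@](C)(/C=C/c2ccc(O)c(/C=C/C#N)c2)CCC=C(C)C)cc1`: 16500 nM
Compound 3 `COc1ccc(/C=C/[C@@](C)(/C=C/c2ccc(O)c(/C=C/C(=O)OC(C)(C)C)c2)CCC=C(C)C)cc1`: > 43400 nM (a limit)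

Compound 3 has no exact number, only the limit > 43400 nM. It sits at the limit of > 43400 nM in this assay, at which 2 of the 3 values shown sit.

Compound 4 `COc1ccc(/C=C/[C@@](C)(/C=C/c2ccc(O)c(/C=C/C(C)=O)c2)CCC=C(C)C)cc1` carries methyl in place of tert-butoxy on a carbonyl carbon.

Among the measured compounds shown here, two steps bear on this change. The first is an at least 2.6-fold higher number from compound 2 to compound 3 (0.42 log units; beyond the scatter), where tert-butoxycarbonyl replaced cyano. The second is an at least 2.6-fold lower number from compound 1 to compound 2 (0.42 log units; beyond the scatter), where 2-cyanoethenyl replaced formyl. The step that the two limits leave unreadable from compound 1 to compound 3 gives no usable size. Losing the tert-butoxy may therefore regain part of the modest gap to compound 2, so a lower number is expected.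

The expected change is an at least 2.4-fold lower number from compound 3 to compound 4 (0.38 log units; beyond the scatter).

For compound 4 the estimated value is 18000 nM, with an expected range of 6000 nM to 43400 nM.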

Compound 4, half-maximal effective concentration: > 43400 nM
Compound 4: no number, only a limit; the forecaster's own chance of this, stated with the estimate: 30%; middle value at least 2.4-fold (0.38 log units) from the limit.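

In this assay, acetyl in place of cyano gives an at least 2.6-fold higher number from compound 2 to compound 4 (0.42 log units; beyond the scatter), so removing the tert-butoxy alone does not bring back a measurable effect. Compound 4 gives > 43400 nM, a limit, and its steps to compound 1 and compound 3 cannot be read. Of the four compounds, only compound 2, with its nitrile, has an exact number: the limit of > 43400 nM in this assay, at which 3 of the 4 values shown sit.

From the compounds shown here alone, whether an amide or a carboxylic acid at the end of this ethenyl chain would also give an exact number stays open. Going by these compounds, how compound 3 and compound 4 truly compare also stays open.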